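This account rests on a few compounds, and the source may have more. Where it says the series, first, only, none or still open, it means among the compounds named here.

For the measured compounds named here, in a functional assay on PC-12 cells (Rattus norvegicus) for cytotoxicity, read by MTT assay, with stated times of 2 h and 24 h, tested at 1 uM (a higher number here means a stronger effect of the compound at the concentration tested, a lower number a weaker effect), compound 2 `Oc1cc(C(F)(F)F)ccc1-c1nc(-c2ccccc2O)n(-c2ccc(C(F)(F)F)cc2)n1` gives 70.7%, the smaller of the two numbers measured so far, a gap that lies within the scatter of compound 1 `Cc1ccc(-n2nc(-c3ccc(C(F)(F)F)cc3O)nc2-c2ccccc2O)cc1`, which gives 71.5%. Compound 3 `Oc1cc(C(F)(F)F)ccc1-c1nc(-c2ccccc2O)n(-c2ccc(Cl)cc2Cl)n1` differs from compound 2 by 2,4-dichlorophenyl in place of 4-(trifluoromethyl)phenyl on an aromatic nitrogen. Going by the values given here, the one measured step bearing on the group at this aromatic nitrogen, a number 0.8 percentage points lower from compound 1 to compound 2 (within the scatter), stayed within the scatter, so no step beyond the scatter is expected here either. Compound 3 is therefore estimated at 70%, with a range from 55% to 84%, an expected step of a number 0.7 percentage points lower from compound 2 to compound 3 (within the scatter).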

Compound 3, a percentage reported as activity, at one concentration (the size of the read-out at that concentration, not a potency): 69%
Compound 3: middle estimate off by 1 percentage points, on the high side; low and high end bracket the measured number.
By their numbers in this assay, from the lowest: compounds 3, 2 and 1 (each within the scatter of the next).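

In this assay, 2,4-dichlorophenyl in place of 4-(trifluoromethyl)phenyl on the aromatic nitrogen gives a number 1.7 percentage points lower from compound 2 to compound 3 (within the scatter) and 2,4-dichlorophenyl in place of 4-methylphenyl gives a number 2.5 percentage points lower from compound 1 to compound 3 (within the scatter) at this position. A second chlorine-bearing change of the ring pattern thus joins the earlier methyl and trifluoromethyl comparison, and none of the three steps leaves the scatter. No measurement shown offers a reason for this. As far as these compounds go, every group here is a substituted phenyl ring, so a carboxylic acid or an amine on that ring remains open. So does an unsubstituted phenyl or a saturated cyclohexyl ring on this nitrogen.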